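This account rests on a few compounds, and the source may have more. Where it says the series, first, only, none or still open, it means among the compounds named here.

In a functional assay on DU-145 cells (Homo sapiens) for cytotoxicity, read by trypan blue exclusion, with a stated time of 96 h (on this read-out lower numbers stand for stronger inhibition and higher numbers for weaker inhibition), compound 1 `COc1cc(OC)c(/C=C/S(=O)(=O)Cc2ccc(OC)cc2[N+](=O)[O-])c(OC)c1` gives 20000 nM and compound 2 `COc1ccc(CS(=O)(=O)/C=C/c2cc(OC)c(OC)c(OC)c2)cc1N` gives 3000 nM. Compound 2 therefore has the lower of the two numbers, a gap beyond the usual scatter, although it is still a micromolar-range result rather than a strong one. Compound 3 `COc1ccc(CS(=O)(=O)/C=C/c2cc(OC)c(OC)c(OC)c2)cc1NCC(=O)O` differs from compound 2 in one place: carboxymethyl stands in place of hydrogen on a nitrogen on an aromatic ring, (carboxymethyl in place of hydrogen on a nitrogen on an aromatic ring). Within the data shown here, no measured pair of compounds shows what this kind of change does, so any forecast here is loose. The expected result is a small shift towards weaker inhibition, with an estimated 1.7-fold higher number from compound 2 to compound 3 (0.22 log units; within the scatter), which would not go beyond the scatter. For compound 3 the estimated value is 5000 nM, with a range from 1000 nM to 20000 nM.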

Compound 3, half-maximal inhibitory concentration: 5000 nM
The estimate for compound 3 equals the measured number at the digits printed, within the range that was stated.
By their numbers in this assay, from the lowest: compounds 2 and 3 (each within the scatter of the next); then compound 1.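

In this assay, putting carboxymethyl in place of hydrogen on the nitrogen on the aromatic ring gives a 1.7-fold higher number from compound 2 to compound 3 (0.22 log units; within the scatter), so this read-out does not separate the two compounds. This nitrogen can therefore carry a group of 4 heavy atoms, including a carbonyl and a hydrogen-bond donor, without a change that stands out from the scatter, although neither compound reaches a strong result. No separate measurement bears on this result.

From the compounds shown here alone, it remains open whether a small group such as methyl or acetyl on this nitrogen would give a number that differs beyond the scatter. The same question applies to a longer chain ending in a carboxylic acid, or to the methyl ester of the carboxymethyl group.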